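The compounds below may be only part of what the source reports. "The series", "measured", "known", "first", "only" and "open" are said of these compounds alone.

Measured in a functional assay on SK-OV-3 cells (Homo sapiens) for cytotoxicity, read by sulforhodamine B assay, with a stated time of 48 h; on this read-out lower numbers stand for stronger inhibition of growth and higher numbers for weaker inhibition of growth:
compound 1 `ClCc1ccc(Cn2cnc3nc(Cl)nc(Cl)c32)cc1` — 2340 nM
compound 2 `ClCc1ccccc1Cn1cnc2ncnc(Cl)c21` — 7580 nM
compound 3 `Nc1nc(Cl)c2ncn(Cc3ccccc3CCl)c2n1` — 15500 nM

Compound 2 stands second highest of the three numbers: compound 3 sits beyond the scatter on the weaker side, compound 1 beyond the scatter on the stronger side. Compound 4 `ClCc1ccccc1Cn1cnc2nc(Cl)nc(Cl)c21` is not yet measured. It differs from compound 2 by chloro in place of hydrogen on an aromatic carbon. No step between two measured compounds covers this change alone, but compound 1, which also carries the added chloro group, gives 2340 nM and is the lowest number shown. A moderate downward step is expected for compound 4, a 1.9-fold lower number from compound 2 to compound 4 (0.28 log units; within the scatter), the number landing between compound 2 and compound 1. Compound 4 is estimated at 4000 nM, with a range of 1500 nM to 10000 nM.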

Compound 4, concentration for 50% growth inhibition: 5880 nM
For compound 4 the middle estimate is 1.5-fold (0.17 log units) below the measured one; low and high end bracket the measured number.
By their numbers in this assay, from the lowest: compound 1; then compounds 4 and 2 (each within the scatter of the next); then compound 3.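

In this assay, chloro in place of hydrogen on the aromatic carbon between two ring nitrogen atoms gives a 1.3-fold lower number from compound 2 to compound 4 (0.11 log units; within the scatter), within the scatter, so this position accepts the added chloro group without a readable shift in growth inhibition. The earlier compounds shown here held no pair that isolated this change. Nothing measured here gives a reason for this result.

From the compounds shown here alone, whether a methoxy or methyl group on this carbon would read the same stays open. The compounds shown also leave open whether this result holds on any other cell line.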